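Swapping the benzothiazole amide for a tolylethyl chain

A few compounds are considered here, and "the series" means these few. Any claim that something is new, unique, unknown or untested is made for them only; others in the source may bear on it.

Of the compounds shown here, three sharing the same chlorophenylpiperidine amide core have been measured in an assay on THP-1 cells for displacement of a labelled ligand from C-C chemokine receptor type 1 (Homo sapiens); a lower number here means a stronger inhibitor, a higher number a weaker inhibitor. Compound 1 `CC[C@@H](NC(=O)CC(C)C)C(=O)N1CCC(c2ccc(Cl)cc2)CC1` gives 152 nM, compound 3 `CC[C@@H](C)[C@@H](NC(=O)c1ccccc1)C(=O)N1CCC(c2ccc(Cl)cc2)CC1` gives 45 nM, and compound 2 `CC(C)[C@@H](NC(=O)c1nc2ccccc2s1)C(=O)N1CCC(c2ccc(Cl)cc2)CC1` gives 18 nM. Compound 2 therefore holds the lowest of the three numbers; its gap to compound 3 and its larger gap to compound 1 both lie beyond the usual scatter, so it is the strongest inhibitor of the set.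

Compound 4 `Cc1cccc(CCC(=O)N[C@@H](C(=O)N2CCC(c3ccc(Cl)cc3)CC2)C(C)C)c1` has not yet been measured. It differs from compound 2 in one place: 2-(3-methylphenyl)ethyl in place of 1,3-benzothiazol-2-yl on a carbonyl carbon. Among the compounds with values here, no measured pair shows this exact change, so any expectation rests on what the three values suggest. Compound 1, whose carbonyl also carries a saturated chain rather than an aromatic ring, gives 152 nM, and compound 3 with a plain aromatic acyl group gives 45 nM. On that basis the step of a 4.4-fold higher number from compound 2 to compound 4 (0.65 log units; beyond the scatter) is expected to be a moderate loss, and compound 4 is estimated at 80 nM, most likely between 25 nM and 250 nM.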

Compound 4, half-maximal inhibitory concentration: 22 nM
The estimate for compound 4 lay 3.6-fold (0.56 log units) above the measured number; the measured number lies below the stated range.
By their numbers in this assay, from the lowest: compounds 2 and 4 (each within the scatter of the next); then compound 3; then compound 1.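

In this assay the exchange of 1,3-benzothiazol-2-yl for 2-(3-methylphenyl)ethyl on the carbonyl carbon gives a 1.2-fold higher number from compound 2 to compound 4 (0.09 log units; within the scatter) and so does not separate the two groups at this position. The exchange removes a five-membered aromatic ring with 2 hetero atoms and 2 hydrogen-bond acceptors, which shows that neither feature is needed for a number of this size in this series pair. Nothing at hand accounts for how closely the two numbers agree. Still open, on these data alone, is whether the methyl group or the two-carbon ethyl link matters, which a plain 2-phenylethyl group, a benzyl group or a longer 3-phenylpropyl chain would test. Also open, as far as these compounds go, is how an amine or a carboxylic acid on the phenyl ring would read.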